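What Hydrogen in Place of Ethoxycarbonyl May Do

The source may report more compounds than this note shows. Statements on the series, on what has been measured and on what is new or still open speak of the compounds shown alone.

In an ADME assay on MT4 cells (Homo sapiens) for cytotoxicity, read by MTT assay (on this read-out higher numbers stand for lower toxicity in this test and lower numbers for higher toxicity in this test), compound 1 (`O=C(CSc1nncnc1-c1cccc2ccccc12)Nc1ccc(Cl)cc1Cl`) gives 254000 nM and compound 2 (`CCOC(=O)c1ccc(NC(=O)CSc2nncnc2-c2cccc3ccccc23)c(Cl)c1`) gives 150000 nM so these two numbers, the only ones so far, stand within the scatter of each other. Compound 3 (`O=C(CSc1nncnc1-c1cccc2ccccc12)Nc1ccccc1Cl`) has not yet been measured. It differs from compound 2 by hydrogen in place of ethoxycarbonyl on an aromatic carbon and that carbon sits meta to a chloro group and para to a large group. Among the compounds with values here, one measured step touches the same carbon, with ethoxycarbonyl in place of chloro. Within the data shown here, no compound with hydrogen at that place has a number yet, so the guide is thin. Since that one step came to a 1.7-fold lower number from compound 1 to compound 2 (0.23 log units; within the scatter) no step beyond the scatter is expected in this assay for the new change. The step estimated from this reasoning is a 1.3-fold higher number from compound 2 to compound 3 (0.12 log units; within the scatter) and it should not be read as a real direction. Compound 3 is expected at about 200000 nM (estimated range 100000 nM to 380000 nM).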

Compound 3, half-maximal cytotoxic concentration: 63000 nM
The estimate for compound 3 lay 3.2-fold (0.50 log units) above the measured number; measured number below the stated range.
By their numbers in this assay, from the lowest: compound 3; then compounds 2 and 1 (each within the scatter of the next).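

In this assay hydrogen in place of ethoxycarbonyl brings a 2.4-fold lower number from compound 2 to compound 3 (0.38 log units; beyond the scatter) and hydrogen in place of chloro brings a 4.0-fold lower number from compound 1 to compound 3 (0.61 log units; beyond the scatter) on the same carbon, the one meta to a chloro group and para to a large group. Compound 1 and compound 2 alone could not show that this carbon matters, since their numbers stand within the scatter of each other; compound 3 now shows that, across these three compounds, the number falls, and so toxicity in this test rises, only when neither chloro nor ethoxycarbonyl sits on that carbon. Nothing available here explains why hydrogen behaves differently from the other two groups.

Within the data shown here, with only three compounds, it remains open whether an amine, a carboxylic acid, a methyl group or a longer chain on this carbon would give a number like that of compound 3 or like those of compound 1 and compound 2. As far as these compounds go, it also remains open whether a group on another carbon of the same ring would have a similar effect.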